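Amide replacement on the alkyne-linked series

A few compounds are considered here, and "the series" means these few. Any claim that something is new, unique, unknown or untested is made for them only; others in the source may bear on it.

Measured so far in a functional assay on TREX cells for negative allosteric modulation of metabotropic glutamate receptor 3 (Rattus norvegicus), read by calcium flux, with a stated time of 2.5 min; on this read-out higher numbers stand for weaker inhibition and lower numbers for stronger inhibition:
- compound 1 `COc1ccc(C#Cc2ccc(C(=O)N3CC[C@@H](O)C3)cc2)cc1` — 10200 nM
- compound 2 `COc1ccc(-c2nnc(-c3ccc(C(=O)N4CCC[C@@H](CO)C4)cc3)o2)cc1` — a limit of the assay, > 10000 nM
- compound 3 `O=C(c1ccc(C#Cc2ccc(Oc3ccccc3)cc2)cc1)N1CCC[C@@H](CO)C1` — a limit of the assay, > 10000 nM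

Compound 1 stands as the only entry that returns a number in this assay; the other two sit at the limit of > 10000 nM in this assay, at which 2 of the 3 values shown sit, which is a limit and not a measured number.

Compound 4 `COc1ccc(C#Cc2ccc(C(=O)N3CC4CCC(=O)C4C3)cc2)cc1` differs from compound 1 in one place: a group of 9 heavy atoms (7 carbon, 1 nitrogen, 1 oxygen; one five-membered non-aromatic ring of carbon only, one five-membered non-aromatic ring with 1 hetero atom) in place of a group of 6 heavy atoms (4 carbon, 1 nitrogen, 1 oxygen; one five-membered non-aromatic ring with 1 hetero atom), on a carbonyl carbon.

Among the compounds with values here, no step between measured compounds is available here, so the expectation for compound 4 rests on compound 1 alone. The step of a 1.3-fold lower number from compound 1 to compound 4 (0.11 log units; within the scatter) is estimated to fall within the usual scatter, with no clear direction. Compound 4 is therefore expected to give 8000 nM in this assay, with a range from 2500 nM to 30000 nM.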

Compound 4, half-maximal inhibitory concentration: 2750 nM
Compound 4: middle estimate off by 2.9-fold (0.46 log units), on the high side; the measured number falls inside the stated range.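

In this assay, within the data shown here, the change on the carbonyl carbon gives a 3.7-fold lower number from compound 1 to compound 4 (0.57 log units; beyond the scatter), the first readable step. This position therefore accepts a group with a second five-membered ring and no hydrogen-bond donor without loss of inhibition. The replacement changes several features at once, so the step cannot be assigned to any one of them.

From the compounds shown here alone, whether the step belongs to the added carbon ring, its carbonyl or the lost hydroxyl stays open, and a plain pyrrolidine amide would help separate these. Compound 2 and compound 3 each give only a limit, not a number, and no step to either can be read: the limit of > 10000 nM in this assay, at which 2 of the 4 values shown sit.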